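The source may hold more compounds than are shown below. What is called first, only, known or untested is meant among the compounds shown, and "the series" means these compounds.

Compound 2 `O=C(CSc1nnc(-c2ccncc2)o1)N/N=C/c1cc(Cl)ccc1O` gives 166000 nM in an ADME assay on NIH3T3 cells (Mus musculus) for cytotoxicity, read by MTT assay, with a stated time of 24 h; a lower number here means a stronger inhibitor, a higher number a weaker inhibitor; compound 1 `O=C(CSc1nnc(-c2ccncc2)o1)N/N=C/c1ccccc1O` gives 155000 nM, and the two numbers lie within the scatter of each other, as the step of a 1.1-fold higher number from compound 1 to compound 2 (0.03 log units; within the scatter) shows. Compound 3 `O=C(CSc1nnc(-c2ccncc2)o1)N/N=C/c1cc(Br)cc(Br)c1O` carries 3,5-dibromo-2-hydroxyphenyl in place of 5-chloro-2-hydroxyphenyl on a carbon with a double bond to nitrogen. Among the compounds with values here, the only measured step that bears on this change, adding a halogen to the same ring, stayed within the scatter, so for this assay no step beyond the scatter is expected, the expected step being a 1.0-fold lower number from compound 2 to compound 3 (0.02 log units; within the scatter). Compound 3 is therefore estimated at 160000 nM, with a range from 60000 nM to 400000 nM.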

Compound 3, half-maximal inhibitory concentration: 190000 nM
Compound 3: the middle estimate sits 1.2-fold (0.07 log units) below what was measured, within the range that was stated.
By their numbers in this assay, from the lowest: compounds 1, 2 and 3 (each within the scatter of the next).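

In this assay, 3,5-dibromo-2-hydroxyphenyl in place of 5-chloro-2-hydroxyphenyl stays within the scatter (a 1.1-fold higher number from compound 2 to compound 3 (0.06 log units; within the scatter)), and so does the same group in place of 2-hydroxyphenyl (a 1.2-fold higher number from compound 1 to compound 3 (0.09 log units; within the scatter)). At this position, the dibromo ring therefore cannot be told apart from either the chloro ring or the ring without halogen. No measurement at hand offers an explanation for this.

Still open, from the compounds shown here alone, is whether a non-halogen group on this ring, such as an amine or a carboxylic acid, would separate from these three compounds. Going by these compounds, replacing the ring's hydroxyl with methoxy is equally open.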